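Phenoxy for trifluoromethyl on the benzyl ring of the series

This account rests on a few compounds, and the source may have more. Where it says the series, first, only, none or still open, it means among the compounds named here.

Compound 1 `Cc1n[nH]c(C(=O)O)c1Cc1ccc(C(F)(F)F)cc1` gives 12% in an assay on isolated protein for inhibition of 2-Hydroxyacid oxidase 2 (Homo sapiens), tested at 10 uM; on this read-out lower numbers stand for a weaker effect and higher numbers for a stronger effect at the one concentration tested. Compound 2 `Cc1n[nH]c(C(=O)O)c1Cc1ccc(Oc2ccccc2)cc1` carries the change phenoxy in place of trifluoromethyl on an aromatic carbon relative to compound 1 and in this assay compound 2 gives 43%; the step is a number 31 percentage points higher from compound 1 to compound 2 (beyond the scatter). Compound 3 `Cc1n[nH]c(C(=O)O)c1Cc1ccccc1C(F)(F)F` has the same atoms as compound 1 joined differently, and the difference between the two cores is not broken down here. In this assay compound 3 gives 38%, which lies within the scatter of the number for compound 2 and beyond the scatter above the number for compound 1.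

Compound 4 `Cc1n[nH]c(C(=O)O)c1Cc1ccccc1Oc1ccccc1` has not been measured. It differs from compound 3 by phenoxy in place of trifluoromethyl on an aromatic carbon. Among the measured compounds shown here, this is the same kind of change as the one from compound 1 to compound 2, but not the same: there the place was para to a large group, here it is ortho to a large group. In this assay the step from compound 3 to compound 4 is expected to be a number 14 percentage points higher from compound 3 to compound 4 (beyond the scatter), smaller than the earlier step, which rests on compound 3 already standing at 38% while compound 2 reached only 43% after the earlier change. For the measured compounds named here, for compound 4 the estimate in this assay is 52%, with a range from 30% to 74%, the breadth reflecting that only one earlier instance of this kind of change exists.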

Compound 4, a percentage reported as inhibition, at one concentration (the size of the read-out at that concentration, not a potency): 49%
Compound 4: the middle estimate sits 3 percentage points above what was measured; the range from low to high includes it.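

Carried from the core of compound 1 to the core of compound 3, with the place now ortho to a large group, phenoxy in place of trifluoromethyl keeps its direction in this assay: the result is a number 11 percentage points higher from compound 3 to compound 4 (beyond the scatter). Among the compounds shown here, the size of the step does not carry over with it, and the change cannot be treated as adding a fixed amount on any core: the same change on two cores in this assay, a number 31 percentage points higher (beyond the scatter) from compound 1 to compound 2 and a number 11 percentage points higher (beyond the scatter) from compound 3 to compound 4, 20 percentage points apart, beyond the scatter of two such steps With only two pairs, the notes cannot tell whether the gap follows the place of the group on the ring or some other difference between the cores, and a read-out at a single concentration gives no potency for any of the compounds.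

The compounds shown offer only trifluoromethyl and phenoxy as substituents on the benzyl ring, so it remains open how a nitrile, an amine or a longer chain would read at these places. All four also keep the carboxylic acid, which leaves open whether the phenoxy change would hold its direction on a core with an amide in that position.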